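The source may hold more compounds than are shown below. What is called first, only, known or untested is meant among the compounds shown, and "the series" means these compounds.

Measured so far in an ADME assay on Vero cells (Chlorocebus sabaeus) for cytotoxicity, read by fluorescence and resazurin assay, with a stated time of 3 days; on this read-out higher numbers stand for lower toxicity in this test and lower numbers for higher toxicity in this test:
- compound 1 `CC1(C)O[C@H]2O[C@H]([C@H](CC(=O)O)n3cnc4c(N)ncnc43)[C@H](Oc3ccccc3N)[C@H]2O1`: 67100 nM
- compound 2 `CCOC(=O)C[C@@H]([C@H]1O[C@@H]2OC(C)(C)O[C@@H]2[C@H]1Oc1ccccc1N)n1cnc2c(N)ncnc21`: 89700 nM

With only these two numbers, compound 2 at 89700 nM stands level with compound 1 within the scatter, and both numbers are large ones. The next case is compound 3 `CCOC(=O)C[C@@H]([C@H]1O[C@@H]2OC(C)(C)O[C@@H]2[C@H]1Oc1ccccc1[N+](=O)[O-])n1cnc2c(N)ncnc21`, which has nitro in place of amino on an aromatic carbon, the change from 2-aminophenoxy to 2-nitrophenoxy (nitro in place of amino on an aromatic carbon). The rest of the molecule stays as in compound 2.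

Going by the values given here, only one measured step is available, a 1.3-fold higher number from compound 1 to compound 2 (0.13 log units; within the scatter), with ethyl in place of hydrogen. It lies at a different place in the molecule, so it bears only indirectly on this change. It shows that one alteration of this series left this assay within the scatter. Among the compounds with values here, no pair tests the amino group itself, so the direction stays open and the range has to be wide. No step beyond the scatter is expected in this assay. The estimated step is a 1.3-fold lower number from compound 2 to compound 3 (0.11 log units; within the scatter). For compound 3 the expected value is 70000 nM, with an estimated range of 25000 nM to 170000 nM.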

Compound 3, half-maximal cytotoxic concentration: 96300 nM
For compound 3 the middle estimate is 1.4-fold (0.14 log units) below the measured one; measured number inside the range.
By their numbers in this assay, from the lowest: compounds 1, 2 and 3 (each within the scatter of the next).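

In this assay, going by these compounds alone, nitro in place of amino on an aromatic carbon gives the first measured step at this place (a 1.1-fold higher number from compound 2 to compound 3 (0.03 log units; within the scatter)), so the exchange of 2-aminophenoxy for 2-nitrophenoxy leaves the read-out within the scatter. Together with the earlier step at the ester end (a 1.3-fold higher number from compound 1 to compound 2 (0.13 log units; within the scatter)), this means that changes in two separate places have now been read, and neither goes beyond the scatter in this assay. Nothing available explains why the numbers stay level at this aromatic carbon.

Still open, on these data alone, is whether other groups on this aromatic carbon, such as a hydroxyl, a methoxy or a carboxylic acid, or a plain phenoxy with only hydrogen there, would also stay within the scatter of compound 2. Also open, as far as these compounds go, is whether the 2-nitrophenoxy group gives the same result alongside a free carboxylic acid or an amide in place of the ethyl ester, since the step from hydrogen to ethyl has been read only with 2-aminophenoxy in the molecule.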